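Swapping the aryl group on the ring nitrogen

The source may report more compounds than this note shows. Statements on the series, on what has been measured and on what is new or still open speak of the compounds shown alone.

Measured in a functional assay on HOS-TE85 cells (Homo sapiens) for inhibition, read by CCK-8 assay, with a stated time of 72 h; on this read-out higher numbers stand for weaker inhibition and lower numbers for stronger inhibition:
compound 1 `COc1ccc(OC)c(N2C(=O)CSC2c2cccc(C(=O)NCCCCc3ccccc3)c2)c1`: > 1000 nM
compound 2 `O=C(NCCCCn1cccn1)c1cccc(C2SCC(=O)N2c2cccnc2)c1`: > 1000 nM
compound 3 `COc1ccccc1N1C(=O)CSC1c1cccc(C(=O)NCCCCn2cccn2)c1`: 91.7 nM

Compound 1 gives only a limit in this assay, > 1000 nM. Compound 2 likewise gives only a limit, > 1000 nM. Compound 3 gives a number, 91.7 nM. Going by the values given here, the single measured step, an at least 10-fold lower number from compound 2 to compound 3 (1.03 log units; beyond the scatter), concerns a different exchange on the same ring nitrogen and bears on the present step only loosely. Compound 4 `CC(F)(F)c1cccc(N2C(=O)CSC2c2cccc(C(=O)NCCCCc3ccccc3)c2)c1` differs from compound 1 by a group of 10 heavy atoms (8 carbon, 2 fluorine; one six-membered aromatic ring of carbon only) in place of a group of 10 heavy atoms (8 carbon, 2 oxygen; one six-membered aromatic ring of carbon only), on an amide-type nitrogen in a ring. Since compound 1 sits at the limit of > 1000 nM in this assay, at which 2 of the 3 values shown sit, the step to compound 4 cannot be sized downward from the data shown. Compound 4 is therefore expected to stay weak, with the expected step that the limit leaves unreadable from compound 1 to compound 4 small. The estimate for compound 4 is 1500 nM, from 200 nM to 10000 nM.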

Compound 4, half-maximal inhibitory concentration: 29.1 nM
Estimate against measurement, compound 4: 52-fold (1.71 log units) above; the whole stated range lies above it.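

In this assay the aryl group on the ring nitrogen again decides the outcome, now with a different amide chain: there is an at least 34-fold lower number from compound 1 to compound 4 (1.53 log units; beyond the scatter) when 2,5-dimethoxyphenyl gives way to the aryl group carrying two fluorine atoms and no oxygen. The sensitivity of this position is therefore not confined to the pair of compound 2 and compound 3. From the compounds shown here alone, whether a plain phenyl or a nitrile-bearing phenyl on this nitrogen would keep the gain stays open. The true size of the step also stays open because compound 1 gives only a limit: the limit of > 1000 nM in this assay, at which 2 of the 4 values shown sit.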